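From methyl to methoxy: estimating compound 4

The source may report more compounds than this note shows. Statements on the series, on what has been measured and on what is new or still open speak of the compounds shown alone.

Compound 1 `FC(F)(F)c1cccc(NN=C2C(Cl)=C(Cl)C(Cl)=C2Cl)c1`: 110 nM
Compound 2 `Cc1cccc(NN=C2C(Cl)=C(Cl)C(Cl)=C2Cl)c1`: 2000 nM
Compound 3 `Fc1ccc(NN=C2C(Cl)=C(Cl)C(Cl)=C2Cl)cc1`: 600 nM

In a functional assay on RPMI-8226 cells (Homo sapiens) for cytotoxicity, read by MTT assay, with a stated time of 48 h (on this read-out lower numbers stand for stronger inhibition and higher numbers for weaker inhibition), compound 2 stands highest of the three, at 2000 nM. Compound 3 lies lower at 600 nM, and compound 1 lies lowest at 110 nM. Compound 4 `COc1cccc(NN=C2C(Cl)=C(Cl)C(Cl)=C2Cl)c1` has not yet been measured. It departs from compound 2 by methoxy in place of methyl on an aromatic carbon. Among the compounds with values here, only one measured step bears on this change, the large 18-fold higher number from compound 1 to compound 2 (1.26 log units; beyond the scatter), and it involves trifluoromethyl rather than methoxy, so it sets no direct size. A small move towards a lower number in this assay, not clearly beyond the scatter, is expected. The expected step is a 1.7-fold lower number from compound 2 to compound 4 (0.22 log units; within the scatter). For compound 4 the estimated value is 1200 nM, with an expected range of 400 nM to 3000 nM.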

Compound 4, half-maximal inhibitory concentration: > 3000 nM
Compound 4: only a limit was reported; the forecaster's own chance of this, stated with the estimate: 2%; middle value at least 2.5-fold (0.39 log units) away from the limit.
By their numbers in this assay, from the lowest: compound 1; then compound 3; then compound 2. At a limit, above all of these: compound 4.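

In this assay compound 4 is reported only as a limit, > 3000 nM. Methoxy in place of methyl gives an at least 1.5-fold higher number from compound 2 to compound 4 (0.17 log units; that floor lies within the scatter), so this change brings no lowering of the number at this position, though the size of the step is not established. Methoxy in place of trifluoromethyl gives an at least 27-fold higher number from compound 1 to compound 4 (1.43 log units; beyond the scatter), which shows that, of the three groups compared at this position, trifluoromethyl alone gives the low number.

From the compounds shown here alone, how far compound 4 lies past its limit stays open: the limit of > 3000 nM in this assay, at which 1 of the 4 values shown sits. Whether a nitrile or an amine at this position would approach trifluoromethyl also stays open.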